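The source may hold more compounds than are shown below. What is called first, only, known or untested is meant among the compounds shown, and "the series" means these compounds.

Measured compounds in the series:
- compound 1, `CCOc1cc(=O)n(CCCO)c2c1CC(CC=C(C)C)C(C)(C)C2`, 16.6%
- compound 2, `CC(C)=CCC1Cc2c(OCCCNS(=O)(=O)c3ccc(C(F)(F)F)cc3)cc(=O)n(CCCO)c2CC1(C)C`, 0%
- compound 3, `CC(C)=CCC1Cc2c(OCCCNS(=O)(=O)c3ccc(Br)cc3)cc(=O)n(CCCO)c2CC1(C)C`, 3.7%

All three were run in a functional assay on PANC-1 cells (Homo sapiens) for inhibition, read by MTT assay, with a stated time of 24 h, tested at 10 uM; a higher number here means more inhibition at the concentration tested (going by the name of the read-out), a lower number less inhibition. Compound 3 stands second highest of the three numbers; its nearest neighbour is compound 2, which differs by a step that is within the scatter (a number 3.7 percentage points higher from compound 2 to compound 3 (within the scatter)), and its furthest is compound 1, which lies beyond the scatter above it (a number 12.9 percentage points lower from compound 1 to compound 3 (beyond the scatter)). So the one step that moved the read-out beyond noise was the one that built out the hydroxypropyl chain of compound 1 into the arylsulfonamide of compound 3; exchanging bromo for trifluoromethyl on the aromatic carbon did nothing measurable.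

Compound 4, `CC(C)=CCC1Cc2c(OCCCNC(=O)c3ccc([N+](=O)[O-])cc3)cc(=O)n(CCCO)c2CC1(C)C`, is the next step from compound 3: (4-nitrophenyl)carbonyl in place of (4-bromophenyl)sulfonyl on an amine nitrogen. Going by the values given here, no measured pair covers this change. What bears on it is that both arylsulfonamide-bearing compounds, 2 and 3, sit at or near the bottom of the range, and that the only large move seen, compound 1 to compound 3, went downward once such an aryl-capped chain was present. On that basis the expected step of a number 2.3 percentage points higher from compound 3 to compound 4 (within the scatter) is small and not beyond the scatter. Compound 4 is estimated to give 6% in this assay, within a range of 0% to 20%.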

Compound 4, a percentage reported as inhibition, at one concentration (the size of the read-out at that concentration, not a potency): 9.1%
For compound 4 the middle estimate is 3.1 percentage points below the measured one; the measured number falls inside the stated range.
By their numbers in this assay, from the lowest: compounds 2, 3, 4 and 1 (each within the scatter of the next, the first and the last beyond it).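

Replacing (4-bromophenyl)sulfonyl with (4-nitrophenyl)carbonyl on the amine nitrogen gives, in this assay, a number 5.4 percentage points higher from compound 3 to compound 4 (within the scatter) and so does not separate the two compounds. Compounds 2 and 3 differ only in the aromatic substituent and share the sulfonyl link, whereas this step shows that a change of the link and of the aromatic substituent together, on the same amine nitrogen, also produces no step beyond the scatter. No measurement in hand explains this read-out.

The step changes two things at once, so the share of the carbonyl and that of the nitro group cannot be told apart; (4-bromophenyl)carbonyl and (4-nitrophenyl)sulfonyl on the same nitrogen would split them. From the compounds shown here alone, it also remains open whether an unsubstituted amine at the end of the chain, a carboxylic acid in place of the aromatic cap, or a longer chain between the ring oxygen and the nitrogen would move the read-out beyond the scatter.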